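Working notes: cytotoxicity limits across three measured analogues

This account rests on a few compounds, and the source may have more. Where it says the series, first, only, none or still open, it means among the compounds named here.

Measured compounds
Compound 1 `O=C(/C=C/C=C/c1ccccc1)c1c(O)c2ccccc2[nH]c1=O` in an ADME assay on THP-1 cells (Homo sapiens) for cytotoxicity, read by MTT assay, with a stated time of 72 h (a lower number here means a stronger inhibitor, a higher number a weaker inhibitor), gives > 50000 nM, which is a limit of the assay and not a number.
Compound 2 `COc1ccc(/C=C/C(=O)c2c(O)c3ccccc3[nH]c2=O)cc1` in this assay gives > 50000 nM, likewise a limit of the assay.
Compound 3 `O=C(/C=C/c1ccc(C(F)(F)F)cc1)c1c(O)c2ccccc2[nH]c1=O` in this assay gives > 50000 nM, again a limit of the assay.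

Compound 2 stands where every measured value in the series stands: at a limit, with no number of its own, so it cannot be placed above or below the others. Both measured steps, a step that the two limits leave unreadable from compound 1 to compound 2 and a step that the two limits leave unreadable from compound 2 to compound 3, are unreadable for the same reason, as summarised by the limit of > 50000 nM in this assay, at which 3 of the 3 values shown sit.

The unmeasured compound 4 `COc1ccc(/C=C/C(=O)c2c(O)c3ccccc3[nH]c2=O)cc1OC` differs from compound 2 by methoxy in place of hydrogen on an aromatic carbon. Neither measured step bears on this change in a readable way: both alter a group elsewhere, and neither yields a size. Among the measured compounds shown here, what the three values show is only that three different groups on the chain end all leave the readout at the limit.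

In this assay no step beyond the scatter is expected for compound 4. Compound 4 is estimated at 70000 nM, with a range from 30000 nM to 200000 nM, most likely reported as a limit again. The expected step is a step that the limit leaves unreadable from compound 2 to compound 4, that is, no readable change.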

Compound 4, half-maximal inhibitory concentration: > 50000 nM
Compound 4 was reported as a limit (the forecaster's own chance of this, stated with the estimate: 85%); the middle value does not contradict the limit.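

No new step can be read: compound 2 and compound 4 both stand at a limit of the assay and not at a number, as does the whole series: the limit of > 50000 nM in this assay, at which 4 of the 4 values shown sit.

The compounds shown leave open how compound 1, compound 2, compound 3 and compound 4 rank in this assay, and which change to the shared core, if any, would give a readable value.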